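From Butylsulfonyl to Benzylsulfonyl in Compound 3

A few compounds are considered here, and "the series" means these few. Any claim that something is new, unique, unknown or untested is made for them only; others in the source may bear on it.

Of the compounds shown here, three have been tested in a functional assay on RH7777 cells for antagonist activity at lysophosphatidic acid receptor 2 (Homo sapiens), read by calcium flux; on this read-out higher numbers stand for weaker inhibition and lower numbers for stronger inhibition. Compound 1 `COc1ccccc1N1CCN(CC(C)(C)Nc2nc(C(F)(F)F)nc3ccccc23)CC1` gives > 30000 nM, which is a limit of the assay rather than a number. Compound 2 `Cc1noc(-c2ccccc2)c1NC(=O)OC(C)c1ccccc1` gives > 50000 nM, likewise a limit. Going by the values given here, compound 3 `CCCCS(=O)(=O)N1CCN(C[C@H](C)Nc2ncnc3c(C)csc23)CC1` is the only one with a measured number, 6610 nM, so it stands alone among the values shown, the other two sitting at the limit of > 30000 nM in this assay, at which 1 of the 3 values shown sits, and at the limit of > 50000 nM in this assay, at which 1 of the 3 values shown sits.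

Compound 4 `Cc1csc2c(N[C@@H](C)CN3CCN(S(=O)(=O)Cc4ccccc4)CC3)ncnc12` differs from compound 3 by phenyl in place of propyl on a saturated chain carbon bound to a sulfonyl sulfur. Among the compounds with values here, no step between measured compounds is available, so no precedent guides the expectation. The change is expected to shift the number by little, if anything beyond the scatter, with the expected step being a 1.3-fold lower number from compound 3 to compound 4 (0.12 log units; within the scatter). Compound 4 is estimated at 5000 nM, within a range from 1500 nM to 20000 nM.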

Compound 4, half-maximal inhibitory concentration: 1860 nM
Compound 4: the middle estimate sits 2.7-fold (0.43 log units) above what was measured; the range from low to high includes it.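

Benzylsulfonyl in place of butylsulfonyl gives a 3.6-fold lower number from compound 3 to compound 4 (0.55 log units; beyond the scatter), the only step that can be read in this set. It shows that the number responds to the group on this sulfonyl sulfur, and that a phenyl on the saturated chain carbon there is compatible with stronger inhibition. Nothing measured here accounts for the size of this step.

On these data alone, whether the aromatic ring itself matters, or a longer chain such as hexyl would serve equally, stays open. So does the effect of an amine or a carboxylic acid on the benzyl group.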